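The source may report more compounds than this note shows. Statements on the series, on what has been measured and on what is new or still open speak of the compounds shown alone.

Values measured in a functional assay on Raji cells (Homo sapiens) for cytotoxicity, with a stated time of 72 h (on this read-out higher numbers stand for weaker inhibition and lower numbers for stronger inhibition), are these.

Compound 1 `CCOC(=O)/C=C/C=C/C=C/C=C/c1ccc[nH]1` gives 4090 nM

Compound 2 `CCOC(=O)/C=C/C=C/C=C/C=C/c1nccs1` gives > 10000 nM which is a limit

Compound 3 `O=C(/C=C/C=C/C=C/c1ccc[nH]1)c1ccccc1` gives 9890 nM

Within the data shown here, compound 2 therefore has no number in this assay and stands at the limit of > 10000 nM in this assay, at which 1 of the 3 values shown sits, as its only reading, a limit. Compound 4 `CCOC(=O)/C=C/C=C/C=C/C=C/c1[nH]ccc1Cl` differs from compound 2 in one place, and the change is a group of 6 heavy atoms (4 carbon, 1 nitrogen, 1 chlorine; one five-membered aromatic ring with 1 hetero atom) in place of a group of 5 heavy atoms (3 carbon, 1 nitrogen, 1 sulfur; one five-membered aromatic ring with 2 hetero atoms), on a double-bonded chain carbon bound to a double-bonded chain carbon on a double-bonded chain carbon bound to a double-bonded chain carbon. Among the measured compounds shown here, the one measured step that bears on this is an at least 2.4-fold higher number from compound 1 to compound 2 (0.38 log units; beyond the scatter) with 1,3-thiazol-2-yl in place of 1H-pyrrol-2-yl. Read backwards, that step points to a lower number when 1,3-thiazol-2-yl leaves. For the measured compounds named here, the group entering compound 4 is likewise a five-membered aromatic ring with 1 hetero atom, but it also carries chlorine, and no measured step covers that atom. Going by the values given here, compound 3 differs from the others in more than one place and supplies no single-place step. A move towards a lower number is therefore expected, at least as large as the measured step, though its true size stays uncertain. The expected step is an at least 5.0-fold lower number from compound 2 to compound 4 (0.69 log units; beyond the scatter) in this estimate. Compound 4 is estimated at 2000 nM with an expected range from 400 nM to 8000 nM in this assay.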

Compound 4, half-maximal inhibitory concentration: > 10000 nM
Compound 4 was reported as a limit (the forecaster's own chance of this, stated with the estimate: 10%); middle value at least 5.0-fold (0.69 log units) away from the limit.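

The new result shows that the ring of compound 1 is sensitive to a change much smaller than swapping the whole ring: in this assay, chloro in place of hydrogen on an aromatic carbon gives an at least 2.4-fold higher number from compound 1 to compound 4 (0.38 log units; beyond the scatter). Compound 4 keeps a five-membered aromatic ring with 1 hetero atom on the chain, so this ring type alone is not enough to hold the reading of compound 1, which the thiazole case of compound 2 could not reveal. The reading of compound 4 is a limit, compound 2 also gives a limit, and the step between them therefore cannot be read, which leaves the two groups unranked against each other: the limit of > 10000 nM in this assay, at which 2 of the 4 values shown sit.

The compounds shown leave open whether this loss belongs to chloro itself or would also follow from a methyl or a fluoro on the same ring. They also leave open how the core of compound 1 would read with a carboxylic acid or an amide in place of its ethyl ester.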